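The source may hold more compounds than are shown below. What is called first, only, known or untested is meant among the compounds shown, and "the series" means these compounds.

Measured so far:
- compound 1, `Cc1cccc(O[C@@H]2CC[C@@H](C)N(C(=O)c3ccccc3-n3nccn3)C2)n1` — in an assay on CHO-K1 cells for displacement of a labelled ligand from Orexin receptor type 2 (Homo sapiens), read by radioligand binding (on this read-out lower numbers stand for stronger inhibition and higher numbers for weaker inhibition), compound 1 gives 7.6 nM
- compound 2, `C[C@@H]1CC[C@@H](Oc2cc(Br)ccn2)CN1C(=O)c1ccccc1-n1nccn1` — in this assay compound 2 gives 1.8 nM

Among the measured compounds shown here, compound 2 holds the lowest number of the two measured; its only neighbour is compound 1, and the one measured step reads a 4.2-fold lower number from compound 1 to compound 2 (0.63 log units; beyond the scatter). Compound 3, `Cc1cccnc1O[C@@H]1CC[C@@H](C)N(C(=O)c2ccccc2-n2nccn2)C1`, is not yet measured. It differs from compound 2 in one place: 3-methylpyridin-2-yl in place of 4-bromopyridin-2-yl on an oxygen on a saturated carbon. For the measured compounds named here, the only step that bears on this place is the one from compound 1 to compound 2, where a methyl-bearing pyridinyl was replaced by the bromo-bearing one and the number dropped modestly. Compound 3 returns to a methyl-bearing pyridinyl, with the methyl named differently, so the change runs in the reverse sense of that step; how far the differently placed methyl tracks compound 1 is not shown by any measured pair. The expectation is therefore a modest rise back toward compound 1, roughly a 2.8-fold higher number from compound 2 to compound 3 (0.44 log units; beyond the scatter). Compound 3 is estimated at 5 nM in this assay, with a range from 2 nM to 15 nM.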

Compound 3, inhibition constant: 621 nM
The estimate for compound 3 lay 120-fold (2.09 log units) below the measured number, outside the stated range (above it).
By their numbers in this assay, from the lowest: compound 2; then compound 1; then compound 3.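

Working notes: in this assay the group on the oxygen on a saturated carbon is far less forgiving than the first step suggested, since 3-methylpyridin-2-yl in place of 4-bromopyridin-2-yl gives a 350-fold higher number from compound 2 to compound 3 (2.54 log units; beyond the scatter), and 3-methylpyridin-2-yl in place of 6-methylpyridin-2-yl gives an 82-fold higher number from compound 1 to compound 3 (1.91 log units; beyond the scatter). The second of these steps keeps a methylpyridin-2-yl group and changes only where the methyl stands, as the group names show, yet it is much larger than the earlier change of a 4.2-fold lower number from compound 1 to compound 2 (0.63 log units; beyond the scatter), so at this position the placement of a methyl alone can outweigh the exchange of methyl for bromo. No measurement on these compounds accounts for the size of this loss.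

Still open, from the compounds shown here alone, is whether the loss follows the methyl itself or any group at that place on the ring, which an unsubstituted pyridin-2-yl and a 3-bromopyridin-2-yl would help to separate. A 4-methylpyridin-2-yl would likewise show whether the low number of compound 2 follows the bromine or the place it occupies.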